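Trifluoromethyl for methyl on the compound 3 aryl ring

The source may report more compounds than this note shows. Statements on the series, on what has been measured and on what is new or still open speak of the compounds shown alone.

In a functional assay on A549 cells (Homo sapiens) for antiproliferative activity, read by MTT assay, with a stated time of 72 h (a higher number here means a weaker inhibitor, a lower number a stronger inhibitor), compound 3 `COc1cc(-c2nc(N(C)C)sc2-c2ccc(C)cc2)cc(OC)c1OC` gives 3960 nM. This lies within the scatter of the two other measured compounds: compound 1 `CNc1nc(-c2cc(OC)c(OC)c(OC)c2)c(-c2ccc(C(F)(F)F)cc2)s1` gives 4570 nM and compound 2 `COc1cc(-c2nc(N(C)C)sc2-c2ccc3ccccc3c2)cc(OC)c1OC` gives 2900 nM. The next analogue, compound 4 `COc1cc(-c2nc(N(C)C)sc2-c2ccc(C(F)(F)F)cc2)cc(OC)c1OC`, carries one change, trifluoromethyl in place of methyl on an aromatic carbon, para to a large group.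

For the measured compounds named here, only one measured step bears directly on this place. That is a 1.4-fold higher number from compound 2 to compound 3 (0.14 log units; within the scatter), where 4-methylphenyl replaces naphthalen-2-yl, and it stays within the scatter. Compound 1 already carries the 4-(trifluoromethyl)phenyl group and differs from compound 4 elsewhere on the shared core; the value of compound 1, 4570 nM, stays close to the others. No step beyond the scatter is therefore expected in this assay, and no direction can be favoured. The expected change is a 1.0-fold lower number from compound 3 to compound 4 (0.02 log units; within the scatter). For compound 4 the estimate is 3800 nM, with an expected range of 1800 nM to 8000 nM.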

Compound 4, half-maximal inhibitory concentration: > 10000 nM
Compound 4: a limit, no number; the forecaster's own chance of this, stated with the estimate: 3%; middle value at least 2.6-fold (0.42 log units) from the limit.
By their numbers in this assay, from the lowest: compounds 2, 3 and 1 (each within the scatter of the next). At a limit, above all of these: compound 4.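

In this assay, this position proved sensitive to the group it carries: trifluoromethyl in place of methyl gives an at least 2.5-fold higher number from compound 3 to compound 4 (0.40 log units; beyond the scatter), whereas the earlier change from naphthalen-2-yl to 4-methylphenyl gave only a 1.4-fold higher number from compound 2 to compound 3 (0.14 log units; within the scatter). The 4-(trifluoromethyl)phenyl group in place of naphthalen-2-yl gives an at least 3.4-fold higher number from compound 2 to compound 4 (0.53 log units; beyond the scatter), and, with that group held constant, methyl in place of hydrogen on the nitrogen gives an at least 2.1-fold higher number from compound 1 to compound 4 (0.34 log units; beyond the scatter), so the outcome at this position also depends on the substitution of that nitrogen. For compound 4 the reading is a limit and not a number, so each of these steps is a minimum: the limit of > 10000 nM in this assay, at which 1 of the 4 values shown sits.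

From the compounds shown here alone, how far compound 4 lies beyond that limit remains open. So does the outcome with a methoxy group, a chlorine atom or a nitrile at this place.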